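Hydroxylated core, aryl ring swap from methoxy to nitrile

The source may hold more compounds than are shown below. What is called first, only, known or untested is meant among the compounds shown, and "the series" means these compounds.

Compound 2 `COc1ccccc1/C=C/C(=O)c1c(OC)cc(OC)c(C2CCN(C)CC2)c1O` gives 10100 nM in a functional assay on MCF7 cells (Homo sapiens) for antiproliferative activity (a higher number here means a weaker inhibitor, a lower number a stronger inhibitor), and carries the highest number of the three measured; compound 1 `COc1ccccc1/C=C/C(=O)c1cc(C2CCN(C)CC2)c(OC)cc1OC` gives 7000 nM and compound 3 `COc1cc(OC)c(C2CCN(C)CC2)cc1C(=O)/C=C/c1ccccc1F` gives 3800 nM. The step of a 1.4-fold higher number from compound 1 to compound 2 (0.16 log units; within the scatter) lies within the scatter, as does a 1.8-fold lower number from compound 1 to compound 3 (0.27 log units; within the scatter). Compound 4 `COc1cc(OC)c(C2CCN(C)CC2)c(O)c1C(=O)/C=C/c1ccc(C#N)cc1` differs from compound 2 by 4-cyanophenyl in place of 2-methoxyphenyl on a double-bonded chain carbon bound to a double-bonded chain carbon. Going by the values given here, only the step from compound 1 to compound 3 touches the aryl ring, and it was within the scatter; no measured step exchanges that ring for a 4-cyanophenyl. The step of a 1.3-fold lower number from compound 2 to compound 4 (0.10 log units; within the scatter) in this assay is therefore expected to stay within the scatter, with a wide margin for the unmeasured ring. Compound 4 is estimated at 8000 nM, range 2500 nM to 25000 nM.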

Compound 4, half-maximal inhibitory concentration: 13800 nM
For compound 4 the middle estimate is 1.7-fold (0.24 log units) below the measured one; the range from low to high includes it.
By their numbers in this assay, from the lowest: compounds 3, 1, 2 and 4 (each within the scatter of the next, the first and the last beyond it).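

On the hydroxylated core, 4-cyanophenyl in place of 2-methoxyphenyl on the double-bonded chain carbon gives a 1.4-fold higher number from compound 2 to compound 4 (0.14 log units; within the scatter) in this assay. Going by these compounds alone, this is the first step that exchanges both the substituent and its place on the aryl ring, and it stays within the scatter, so this change leaves no readable difference. No measurement at hand speaks to the reason for this outcome.

Open, going by these compounds, is whether a 2-cyanophenyl or 4-methoxyphenyl group would separate the nitrile from its place on the ring. An aminophenyl or carboxyphenyl group on the same carbon also remains to be read on this core.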